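A few compounds are considered here, and "the series" means these few. Any claim that something is new, unique, unknown or untested is made for them only; others in the source may bear on it.

In a functional assay on L02 cells (Homo sapiens) for inhibition, read by MTT assay, with a stated time of 72 h (a higher number here means a weaker inhibitor, a lower number a stronger inhibitor), compound 1 `C=C(c1cc(Cl)cc(Cl)c1OCc1ccccc1)C1COC2(CCCCC2)OO1` gives > 100000 nM as a limit of the assay and not a number. In this assay compound 2 `C=C(c1ccc(Cl)c(Cl)c1)C1COC(C)(C)OO1` gives 50900 nM and compound 3 `C=C(c1ccc(Cl)c(Cl)c1Cl)C1COC(C)(C)OO1` gives 18100 nM as the lower of the two numbers. Compound 4 `C=C(c1ccc(Cl)cc1Cl)C1COC(C)(C)OO1` follows from compound 3 through hydrogen in place of chloro on an aromatic carbon and this is hydrogen in place of chloro on an aromatic carbon, ortho to two chloro groups. For the measured compounds named here, the only measured step bearing on it is a 2.8-fold lower number from compound 2 to compound 3 (0.45 log units; beyond the scatter) and that modest step added a chloro at another place on the ring. A step of similar size in the opposite direction is therefore expected in this assay toward a higher number. The estimated change is a 2.5-fold higher number from compound 3 to compound 4 (0.40 log units; beyond the scatter) and it rests on that single step. Compound 4 is estimated at 45000 nM with an expected range of 20000 nM to 100000 nM for the measurement.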

Compound 4, half-maximal inhibitory concentration: 37700 nM
Compound 4: the middle estimate sits 1.2-fold (0.08 log units) above what was measured, within the range that was stated.
By their numbers in this assay, from the lowest: compound 3; then compounds 4 and 2 (each within the scatter of the next). At a limit, above all of these: compound 1.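

In this assay, the chloro ortho to two chloro groups proves to matter on its own: replacing it with hydrogen gives a 2.1-fold higher number from compound 3 to compound 4 (0.32 log units; beyond the scatter) and so moves the number beyond the scatter. Read beside a 2.8-fold lower number from compound 2 to compound 3 (0.45 log units; beyond the scatter) this shows that the lower number of compound 3 is lost on removing either of these two chloro groups. Nothing shown gives a cause for this step.

Still open, as far as these compounds go, is whether a methoxy group or an amine on this aromatic carbon would hold the number of compound 3. Also open, from the compounds shown here alone, is whether a bromo group there would do the same.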